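This account rests on a few compounds, and the source may have more. Where it says the series, first, only, none or still open, it means among the compounds named here.

Measured compounds:
compound 1 `CNC(=O)c1cc(Oc2ccc(NC(=O)c3nn(-c4cccc(F)c4)c(=O)cc3C)cc2F)ccn1` — in a functional assay on HepG2 cells (Homo sapiens) for cytotoxicity, read by MTT assay, with a stated time of 72 h (a lower number here means a stronger inhibitor, a higher number a weaker inhibitor), compound 1 gives 10200 nM
compound 2 `CNC(=O)c1cc(Oc2ccc(NC(=O)c3nn(-c4ccc(C)cc4)c(=O)cc3C)cc2F)ccn1` — in this assay compound 2 gives 10600 nM
compound 3 `CNC(=O)c1cc(Oc2ccc(NC(=O)c3nn(-c4ccccc4F)c(=O)cc3C)cc2F)ccn1` — in this assay compound 3 reaches only the assay limit > 40000 nM, which is a limit and not a number the limit of > 40000 nM in this assay, at which 1 of the 3 values shown sits.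

Compound 2 stands among the two numbers actually reported; its nearest neighbour is compound 1, and the step of a 1.0-fold higher number from compound 1 to compound 2 (0.02 log units; within the scatter) lies within the scatter. The step of an at least 3.7-fold higher number from compound 2 to compound 3 (0.57 log units; beyond the scatter) runs to the limit of compound 3.

Compound 4 `Cc1ccc(-n2nc(C(=O)Nc3ccc(Oc4ncnc5ccsc45)c(F)c3)c(C)cc2=O)cc1` is not yet measured. The change from compound 2 is a group of 9 heavy atoms (6 carbon, 2 nitrogen, 1 sulfur; one five-membered aromatic ring with 1 hetero atom, one six-membered aromatic ring with 2 hetero atoms) in place of a group of 10 heavy atoms (7 carbon, 2 nitrogen, 1 oxygen; one six-membered aromatic ring with 1 hetero atom), on an oxygen on an aromatic ring. All three measured steps a 1.0-fold higher number from compound 1 to compound 2 (0.02 log units; within the scatter) an at least 3.9-fold higher number from compound 1 to compound 3 (0.59 log units; beyond the scatter) an at least 3.7-fold higher number from compound 2 to compound 3 (0.57 log units; beyond the scatter) alter the group on the aromatic nitrogen, at the opposite end of the shared core; none touches the group on the aromatic ether oxygen. Among the measured compounds shown here, no measured step therefore bears on the change to compound 4, and no direction beyond the scatter can be expected from the data. Compound 4 is estimated at 9000 nM, with a range from 2500 nM to 32000 nM. This estimate means an expected step of a 1.2-fold lower number from compound 2 to compound 4 (0.07 log units; within the scatter).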

Compound 4, half-maximal inhibitory concentration: 17300 nM
Compound 4: the middle estimate sits 1.9-fold (0.28 log units) below what was measured; the measured number falls inside the stated range.
By their numbers in this assay, from the lowest: compounds 1, 2 and 4 (each within the scatter of the next). At a limit, above all of these: compound 3.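

Among the compounds shown here, the step of a 1.6-fold higher number from compound 2 to compound 4 (0.21 log units; within the scatter) in this assay is the first reading at the aromatic ether oxygen, as all earlier steps changed only the group on the aromatic nitrogen. With the 4-methylphenyl group held constant, the 2-(methylcarbamoyl)pyridin-4-yl group gives way to a group with a five-membered and a six-membered aromatic ring and no hydrogen-bond donor, without a change beyond the scatter, so the donor in the group that leaves is not needed to keep the number at this level. Nothing measured here accounts for this outcome.

As far as these compounds go, whether an amine or a carboxylic acid on the aromatic ether oxygen's group would move the number beyond the scatter stays open. From the compounds shown here alone, compound 3 gives > 40000 nM, which is a limit, and how its 2-fluorophenyl group would behave with the new group also stays open.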